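The source may report more compounds than this note shows. Statements on the series, on what has been measured and on what is new or still open speak of the compounds shown alone.

Compound 1 `Cc1cc(Nc2ccc(S(F)(F)(F)(F)F)cc2)n2nc(C3CC3)nc2n1` was measured in an in vitro ADME assay on microsomes from liver (Mus musculus) for metabolic stability (a higher number here means faster removal of the compound, a lower number slower removal), and gave 12.6 mL.min-1.g-1. Two measured relatives share its core. Compound 2 `Cc1cc(Nc2ccc(C(F)(F)F)cc2)n2nc(C3CC3)nc2n1` gives 8.6 mL.min-1.g-1 in this assay, and compound 3 `CCc1nc2nc(C)cc(Nc3ccc(C(F)(F)F)cc3)n2n1` gives 14.4 mL.min-1.g-1. The three numbers all lie within the usual scatter of one another: the change a 1.5-fold lower number from compound 1 to compound 2 (0.17 log units; within the scatter) is small, as is a 1.7-fold higher number from compound 2 to compound 3 (0.22 log units; within the scatter), so none of the three stands apart from the others.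

The next compound, compound 4 `Cc1cc(Nc2ccc(S(F)(F)(F)(F)F)cc2)n2nc(C(C)(F)F)nc2n1`, differs from compound 1 in one place: 1,1-difluoroethyl in place of cyclopropyl on an aromatic carbon. The measured step that bears on this change is the one in which ethyl replaces cyclopropyl on the same position of the core, a 1.7-fold higher number from compound 2 to compound 3 (0.22 log units; within the scatter), which stayed within the scatter. A 1,1-difluoroethyl group is another small, non-ring replacement for cyclopropyl, so no step beyond the scatter is expected in this assay. The step from compound 1 to compound 4 is estimated as a 1.1-fold lower number from compound 1 to compound 4 (0.02 log units; within the scatter). Compound 4 is therefore expected to give about 12 mL.min-1.g-1 in this assay, most likely between 6 mL.min-1.g-1 and 25 mL.min-1.g-1.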

Compound 4, intrinsic clearance in microsomes: 8.1 mL.min-1.g-1
Estimate against measurement, compound 4: 1.5-fold (0.17 log units) above; the range from low to high includes it.
By their numbers in this assay, from the lowest: compounds 4, 2, 1 and 3 (each within the scatter of the next).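

In this assay, replacing cyclopropyl on this aromatic carbon gives a 1.6-fold lower number from compound 1 to compound 4 (0.19 log units; within the scatter), so the ring can give way here to a non-ring group carrying fluorine without a step beyond the scatter. Within the data shown here, the earlier step at this position, from cyclopropyl to ethyl, was seen only with a trifluoromethyl group on the other aromatic ring; this one shows a similarly small step with the sulfur and fluorine group of compound 1 in that place, and with a different incoming group. No measurement is available that would explain the size of this step.

On these data alone, whether a longer chain, an amine or a carboxylic acid on this carbon would also stay within the scatter remains open. Also open, as far as these compounds go, is how 1,1-difluoroethyl behaves with trifluoromethyl on the other ring.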